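A few compounds are considered here, and "the series" means these few. Any claim that something is new, unique, unknown or untested is made for them only; others in the source may bear on it.

Measured compounds: compound 1 `C=CCc1cc(C(C)=O)c(O)cc1OCCCCCCCCC#N` gives 50% in an assay on isolated protein for binding affinity to leukotriene B4 receptor 1 (Homo sapiens), tested at 1 uM; a lower number here means less inhibition, a higher number more inhibition at the concentration tested (going by the name of the read-out); compound 2 `CCc1cc(C(C)=O)c(O)cc1OCCCCCCC(C)(C)C#N` gives 30%; compound 3 `CCc1cc(C(C)=O)c(O)cc1OCCCCCCS(C)(=O)=O` gives 62%.

Compound 1 stands second highest of the three, with compound 3 above it and compound 2 below, both gaps beyond the scatter. Compound 4 `C=CCc1cc(C(C)=O)c(O)cc1OCCCCCC(=O)NO` differs from compound 1 by hydroxycarbamoyl in place of 3-cyanopropyl on a saturated chain carbon, five bonds along the chain from an oxygen on an aromatic ring. For the measured compounds named here, the only measured step that bears on it is a swap of the group at the end of the chain, a number 32 percentage points higher from compound 2 to compound 3 (beyond the scatter), a large rise. The change to compound 4 also swaps the chain end, but shortens the chain as well, so a smaller rise is expected: a number 8 percentage points higher from compound 1 to compound 4 (within the scatter). Compound 4 is expected at 58%, between 38% and 78%.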

Compound 4, a percentage reported as inhibition, at one concentration (the size of the read-out at that concentration, not a potency): 28%
Compound 4: the middle estimate sits 30 percentage points above what was measured; measured number outside the range, below it.
By their numbers in this assay, from the lowest: compounds 4 and 2 (each within the scatter of the next); then compound 1; then compound 3.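

In this assay, hydroxycarbamoyl in place of 3-cyanopropyl gives a number 22 percentage points lower from compound 1 to compound 4 (beyond the scatter), so at this place on the chain the two ends are not interchangeable. For the compounds shown here, the only earlier step was a rise, so this one adds a first case of a change at the chain end lowering the inhibition. Nothing available explains the drop.

Going by these compounds, this one change both replaces the end group and shortens the chain, so the share of each stays open. A carboxylic acid on the same chain, or hydroxycarbamoyl on a longer chain, would help separate them.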